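Methyl for Trifluoromethyl on a Dichloroacetamide Biaryl

This account rests on a few compounds, and the source may have more. Where it says the series, first, only, none or still open, it means among the compounds named here.

The study concerns three measured dichloroacetamides and one that awaits measurement. Compound 1 `O=C(Nc1cccc(-c2ccccc2C(F)(F)F)c1)C(Cl)Cl` and compound 2 `Cc1ccccc1-c1cccc(NC(=O)C(Cl)Cl)c1` share one core and differ only in that (methyl in place of trifluoromethyl on an aromatic carbon). In a functional assay on A549 cells (Homo sapiens) for cytotoxicity, read by MTT assay, with a stated time of 68 h (a higher number here means a weaker inhibitor, a lower number a stronger inhibitor), compound 1 gives 7500 nM, and in the same assay compound 2 gives 9860 nM, so that the exchange produced a 1.3-fold higher number from compound 1 to compound 2 (0.12 log units; within the scatter). Compound 3 `O=C(Nc1cccc(-c2cccc(C(F)(F)F)c2)c1)C(Cl)Cl` has the same atoms as compound 1 joined differently; the difference between the two cores is not broken down here. In this assay compound 3 gives 18500 nM, a higher number than compound 1 and one that sits within the scatter of compound 2.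

Compound 4 `Cc1cccc(-c2cccc(NC(=O)C(Cl)Cl)c2)c1` has not yet been measured in this assay. It differs from compound 3 in that (methyl in place of trifluoromethyl on an aromatic carbon). This is the same kind of change as that from compound 1 to compound 2, but not the same: in compound 1 the place is ortho to a large group, while in compound 3 it is meta to a large group.

Because the same kind of exchange gave a 1.3-fold higher number from compound 1 to compound 2 (0.12 log units; within the scatter), compound 4 is expected to remain close to compound 3, with an estimated step of a 1.2-fold higher number from compound 3 to compound 4 (0.08 log units; within the scatter). For compound 4 the expected value in this assay is 22000 nM. The estimate for compound 4 is expected to fall between 11000 nM and 45000 nM.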

Compound 4, half-maximal inhibitory concentration: 8700 nM
Compound 4: the middle estimate sits 2.5-fold (0.40 log units) above what was measured; the measured number lies below the stated range.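

On the core of compound 3, putting methyl in place of trifluoromethyl on an aromatic carbon, meta to a large group, gave a 2.1-fold lower number from compound 3 to compound 4 (0.33 log units; beyond the scatter) in this assay and so moved the number in the direction of a stronger inhibitor. This shows that, within these two pairs, the result of the exchange on one core did not carry over to the other, and the step measured on the core of compound 1 would have been a poor guide to this one. It does not show which difference between the cores accounts for the gap or that any property of either group lies behind it, as each core supplies only a single pair in a single cell assay, and the two steps compare as follows: the same change on two cores in this assay, a 1.3-fold higher number (0.12 log units; within the scatter) from compound 1 to compound 2 and a 2.1-fold lower number (0.33 log units; beyond the scatter) from compound 3 to compound 4, 2.8-fold (0.45 log units) apart, beyond the scatter of two such steps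

The compounds shown leave open how other groups at the same place, such as a chlorine atom, a methoxy group, a nitrile or an amine, would behave on each of the two cores. They also leave open whether the gap between the two steps would persist with a carboxylic acid or a longer chain on the same ring, or in cells other than those tested here.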